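Formyl in place of carboxymethyl: compound 3 against compound 1

The source may hold more compounds than are shown below. What is called first, only, known or untested is meant among the compounds shown, and "the series" means these compounds.

Measured so far in a functional assay on P388 cells (Mus musculus) for cytotoxicity; on this read-out lower numbers stand for stronger inhibition and higher numbers for weaker inhibition:
Compound 1 `COc1ccc(C[C@H]2C(=O)N[C@@H](C)C(=O)N(C)[C@H]3Cc4ccc(cc4)Oc4cc(ccc4OC)C[C@@H](C(=O)N[C@H](C)C(=O)N[C@@H](CCC(=O)O)C(=O)N2C)N(C)C3=O)cc1` gives 219 nM.
Compound 2 `COc1ccc(C[C@H]2C(=O)N[C@@H](C)C(=O)N(C)[C@H]3Cc4ccc(cc4)Oc4cc(ccc4OC)C[C@@H](C(=O)N[C@H](C)C(=O)N[C@@H](CCCO)C(=O)N2C)N(C)C3=O)cc1` gives 174 nM.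

Of these two numbers compound 1 stands highest, with compound 2 nearest at a 1.3-fold lower number from compound 1 to compound 2 (0.10 log units; within the scatter). Compound 3 `COc1ccc(C[C@H]2C(=O)N[C@@H](C)C(=O)N(C)[C@H]3Cc4ccc(cc4)Oc4cc(ccc4OC)C[C@@H](C(=O)N[C@H](C)C(=O)N[C@@H](CC=O)C(=O)N2C)N(C)C3=O)cc1` is not yet measured; it differs from compound 1 by formyl in place of carboxymethyl on a saturated chain carbon bound to a saturated ring carbon. Within the data shown here, the only measured step that bears on this change alters the same chain, a 1.3-fold lower number from compound 1 to compound 2 (0.10 log units; within the scatter), and did not move the number beyond the scatter. A step of the same kind is therefore expected from compound 1 to compound 3, none beyond the scatter, a 1.1-fold lower number from compound 1 to compound 3 (0.04 log units; within the scatter). Compound 3 is estimated at 200 nM, within 90 nM to 450 nM, in this assay.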

Compound 3, half-maximal inhibitory concentration: 33.9 nM
The estimate for compound 3 lay 5.9-fold (0.77 log units) above the measured number, outside the stated range (below it).
By their numbers in this assay, from the lowest: compound 3; then compounds 2 and 1 (each within the scatter of the next).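

Working in this assay, this position on a saturated chain carbon bound to a saturated ring carbon proves able to move the number: the change gives a 6.5-fold lower number from compound 1 to compound 3 (0.81 log units; beyond the scatter) and a 5.1-fold lower number from compound 2 to compound 3 (0.71 log units; beyond the scatter), both beyond the scatter. The carboxymethyl and 2-hydroxyethyl groups stay within the scatter of each other, so formyl alone stands apart among the three. Nothing at hand accounts for this gap.

Open, as far as these compounds go, is whether the formyl end or the shorter chain matters, which a formyl on a longer chain could separate. An amine or a carboxylic acid on the shorter chain would test the same question.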